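The compounds below may be only part of what the source reports. "The series", "measured", "known", "first", "only" and "open" are said of these compounds alone.

Compound 1 `CN(C)c1ccnc(Nc2ccc(C#N)cc2)n1`, 34000 nM; compound 2 `Cc1ccccc1COc1ccnc(Nc2ccc(C#N)cc2)n1`, 12000 nM; compound 3 `N#Cc1ccc(Nc2nccc(OCc3ccccc3C(F)(F)F)n2)cc1`, 173000 nM.

In an ADME assay on MT4 cells (Homo sapiens) for cytotoxicity, read by MTT assay, with a stated time of 5 days (on this read-out lower numbers stand for higher toxicity in this test and higher numbers for lower toxicity in this test), compound 2 stands lowest of the three numbers; compound 1 gives 34000 nM and compound 3 gives 173000 nM, the nearest and the furthest from it. Compound 4 `N#Cc1ccc(COc2ccnc(Nc3ccc(C#N)cc3)n2)cc1` differs from compound 2 in one place: 4-cyanophenyl in place of 2-methylphenyl on a saturated chain carbon bound to an oxygen on an aromatic ring.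

Among the measured compounds shown here, only one measured step touches the same ring: a 14-fold higher number from compound 2 to compound 3 (1.16 log units; beyond the scatter). That step swapped one group for another in the same spot, whereas the change to compound 4 removes the methyl altogether and adds a nitrile elsewhere on the ring, so it bears on the new step only loosely. No step is known for compound 1 against compound 2; their values simply differ as shown. He therefore expects a rise in this assay for compound 4, likely modest and possibly no larger than the scatter, given as a 2.5-fold higher number from compound 2 to compound 4 (0.40 log units; beyond the scatter). His estimate for compound 4 is 30000 nM, between 8000 nM and 120000 nM.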

Compound 4, half-maximal cytotoxic concentration: 209000 nM
For compound 4 the middle estimate is 7.0-fold (0.84 log units) below the measured one; measured number outside the range, above it.
By their numbers in this assay, from the lowest: compound 2; then compound 1; then compounds 3 and 4 (each within the scatter of the next).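

In this assay, replacing the whole aryl group gives a 17-fold higher number from compound 2 to compound 4 (1.24 log units; beyond the scatter), so the large rise seen at this position is not confined to a trifluoromethyl group in place of methyl. Read with a 14-fold higher number from compound 2 to compound 3 (1.16 log units; beyond the scatter), it shows two different changes to 2-methylphenyl on the saturated chain carbon bound to an oxygen on an aromatic ring, both moving the number up by a large step, and here the entering 4-cyanophenyl carries one hydrogen-bond acceptor where the leaving group has none. No measurement shown here gives a reason for this rise.

On these data alone, it remains open whether the rise goes with the added nitrile or with the lost methyl, and an unsubstituted phenyl on the same chain carbon would separate the two. Also open, as far as these compounds go, is how 4-cyanophenyl would compare with a phenyl ring carrying a carboxylic acid or an amine in place of the nitrile.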